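Cytotoxicity of a sulfonyl-bearing series: the next analogue

The source may hold more compounds than are shown below. What is called first, only, known or untested is meant among the compounds shown, and "the series" means these compounds.

Compound 1, `N#Cc1ccc2c(c1)S(=O)(=O)C=C(c1c(O)c3cc(F)ccc3n(Cc3ccc(F)cc3)c1=O)N2`, in an ADME assay on 2209-23 cells (Homo sapiens) for cytotoxicity, read by WST assay (a lower number here means that less compound is tolerated, a higher number that more compound is tolerated), gives a value that is a limit of the assay, > 50000 nM.
Compound 2, `CNC(=O)COc1ccc2c(c1)S(=O)(=O)C=C(c1c(O)c3cc(F)ccc3n(Cc3ccc(F)cc3)c1=O)N2`, in this assay gives a limit, > 50000 nM.
Compound 3, `CC(=O)Nc1ccc2c(c1)S(=O)(=O)C=C(c1c(O)c3cc(F)ccc3n(Cc3ccc(F)cc3)c1=O)N2`, in this assay gives a limit, > 50000 nM.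

Compound 3 therefore stands at the upper edge of what this assay reports, and it is not alone there: all three measured compounds sit at the limit of > 50000 nM in this assay, at which 3 of the 3 values shown sit. None of the steps between them can be read. The change from compound 1 to compound 2 gives a step that the two limits leave unreadable from compound 1 to compound 2, that from compound 1 to compound 3 gives a step that the two limits leave unreadable from compound 1 to compound 3, and that from compound 2 to compound 3 gives a step that the two limits leave unreadable from compound 2 to compound 3.

Compound 4, `CN(c1ccc2c(c1)S(=O)(=O)C=C(c1c(O)c3cc(F)ccc3n(Cc3ccc(F)cc3)c1=O)N2)S(C)(=O)=O`, differs from compound 3 in one place: methyl(methylsulfonyl)amino in place of acetamido on an aromatic carbon. Within the data shown here, no measured step offers a readable size for a change of this kind, and the three substituents tried so far all left the series at the limit. Compound 4 is therefore expected to show a number no higher from compound 3 to compound 4 (the limit leaves the size open) in this assay, most likely another limit. The estimate for compound 4 is 50000 nM, with a range from 20000 nM to 120000 nM.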

Compound 4, half-maximal cytotoxic concentration: > 50000 nM
Compound 4: only a limit was reported; the forecaster's own chance of this, stated with the estimate: 85%; the middle value lies on the limit itself.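

Compound 4 also gives a limit in this assay, so its steps from compound 1, compound 2 and compound 3 cannot be read: the limit of > 50000 nM in this assay, at which 4 of the 4 values shown sit.

The compounds shown leave open how the four compare with one another and at what concentration any of them becomes cytotoxic.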